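The source may report more compounds than this note shows. Statements on the series, on what has been measured and on what is new or still open speak of the compounds shown alone.

Working notes on the series, followed in an ADME assay on microsomes from liver (Mus musculus) for metabolic stability, read by LC-MS, with NADPH named in the record, with a stated time of 60 min, tested at 1 uM, in the absence of a further agent; a lower number here means that less of the compound is left, a higher number that more of the compound is left. Compound 3 `CC(=O)N[C@@H]1CCN(c2cc(C)nn3c(-c4ccco4)c(C)nc23)C1` gives > 95%, which is a limit of the assay and not a number. Compound 1 `COc1ccc(-c2c(C)nc3c(N4CC[C@@H](NC(C)=O)C4)cc(C)nn23)cc1F` gives > 95%, also a limit. Compound 2 `CSc1ccc(-c2c(C)nc3c(N4CC[C@@H](NC(C)=O)C4)cc(C)nn23)cc1` gives > 95%, again a limit. These three compounds all stand at the limit of > 95% in this assay, at which 3 of the 3 values shown sit, so compound 3 has no readable position relative to the other two.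

The next change leads to compound 4 `CC(=O)N[C@@H]1CCN(c2cc(C)nn3c(-c4nccs4)c(C)nc23)C1`, with 1,3-thiazol-2-yl in place of furan-2-yl on an aromatic carbon. Three measured steps exchange the group on this same aromatic carbon: a step that the two limits leave unreadable from compound 1 to compound 3, a step that the two limits leave unreadable from compound 2 to compound 3 and a step that the two limits leave unreadable from compound 1 to compound 2. None of them has a readable size, but all three groups in these compounds stay at the limit. No step beyond the usual scatter is therefore expected in this assay, and no direction is expected. The expected step is a step that the limit leaves unreadable from compound 3 to compound 4. Compound 4 is expected at 96%, with an estimated range from 82% to 100%.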

Compound 4, percent of the compound remaining: > 95%
Compound 4: only a limit was reported (the forecaster's own chance of this, stated with the estimate: 70%); the middle value lies beyond the limit too.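

No step from compound 4 to compound 1, compound 2 or compound 3 can be read in this assay, since all four compounds give a limit of the assay and not a number: the limit of > 95% in this assay, at which 4 of the 4 values shown sit.
The compounds shown leave open how far the groups on this aromatic carbon differ in the percent of compound remaining.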